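The compounds below may be only part of what the source reports. "The series", "measured", "known", "first", "only" and "open" are said of these compounds alone.

Measured compounds:
compound 1 `Cn1c(=O)c2c(nc(CCSc3cccc(Br)c3)n2C)n(C)c1=O`, 372000 nM
compound 2 `COc1cccc(OCc2nc3c(c(=O)n(C)c(=O)n3C)n2C)c1`, "not active" (no number reported)
compound 3 `Cn1c(=O)c2c(nc(CCSc3cccc(Cl)c3)n2C)n(C)c1=O`, "not active" (no number reported)

Of the compounds shown here, three built on one shared core have been tested in an in vitro assay on cells for inhibition of Amine oxidase [flavin-containing] A (Homo sapiens), read by coupled enzyme assay, with a stated time of 20 min; a lower number here means a stronger inhibitor, a higher number a weaker inhibitor. Compound 1 gives 372000 nM in this assay, a very high concentration, which makes it a weak inhibitor. Compound 2 is recorded in this assay as "not active" (no number reported), with no number reported. Compound 3 is recorded in this assay as "not active" (no number reported), also without a number. Compound 2 therefore stands among the entries without a number, beside one other such entry, and the only numbered result in the set is itself very weak.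

Compound 4 `Cn1c(=O)c2c(nc(COc3cccc(Cl)c3)n2C)n(C)c1=O` has not yet been measured. It differs from compound 2 in one place: chloro in place of methoxy on an aromatic carbon. Among the measured compounds shown here, no measured pair shows this same change, so its size and direction cannot be read from the data. Since compound 2 gave "not active" (no number reported) and compound 3 gave "not active" (no number reported), I expect compound 4 to remain a very weak inhibitor, with no step beyond the scatter in either direction that the data could support. Compound 4 is estimated at 400000 nM in this assay, within a range from 120000 nM to 1500000 nM, and it is quite possible that the assay again reports no number at all.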

Compound 4, half-maximal inhibitory concentration: "not active" (no number reported)
The entry for compound 4 holds no number; there is nothing to compare the estimate with.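

Compound 2 and compound 4 are both recorded as not active, without a number, so no step can be read between them. No measurement shown offers an explanation for this result. The compounds shown leave open whether chloro in place of methoxy changes inhibition at all, and how far either compound lies from measurable activity.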